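From methyl to oxolan-2-yl on the chain carbon

The compounds below may be only part of what the source reports. "The series", "measured", "known", "first", "only" and "open" are said of these compounds alone.

In an ADME assay on MDCK cells (Canis lupus familiaris) for permeability, read by LC-MS, with a stated time of 90 min, tested at 2 uM (a higher number here means that the compound crosses the layer faster, a lower number that the compound crosses the layer more slowly), compound 3 `Cc1cc(C)c(CN2CCc3c(Cl)cc([C@H](C)CO)c(Cl)c3C2=O)c(=O)[nH]1` gives 12.4 10^-6 cm/s, the higher of the two single numbers, and compound 1 `Cc1cc(C)c(CN2CCc3c(Cl)cc([C@H](CO)[C@H]4CCOC4)c(Cl)c3C2=O)c(=O)[nH]1` gives 2.9 10^-6 cm/s. Compound 2 `Cc1cc(C)c(CN2CCc3c(Cl)cc(C(CO)c4ccon4)c(Cl)c3C2=O)c(=O)[nH]1` has two entries, 5.8 10^-6 cm/s; 8.6 10^-6 cm/s (2 entries), and so no single number.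

Compound 4 `Cc1cc(C)c(CN2CCc3c(Cl)cc([C@@H](CO)[C@@H]4CCCO4)c(Cl)c3C2=O)c(=O)[nH]1` is the next structure to follow from compound 3, and the change is oxolan-2-yl in place of methyl on a saturated chain carbon bound to an aromatic carbon and a saturated chain carbon. In words, oxolan-2-yl stands in place of methyl on a saturated chain carbon bound to an aromatic carbon and a saturated chain carbon.

Among the measured compounds shown here, one measured step bears on this change, a 4.3-fold higher number from compound 1 to compound 3 (0.63 log units; beyond the scatter). That step also exchanges a five-membered non-aromatic ring with 1 hetero atom for a smaller group without a ring. Read in reverse, it points to a lower number of similar size in this assay, beyond the scatter. The step expected here is a 3.3-fold lower number from compound 3 to compound 4 (0.51 log units; beyond the scatter). For the measured compounds named here, with only one step to draw on, the range is kept wide. Compound 4 is estimated at 3.8 10^-6 cm/s, with an expected range of 1.6 10^-6 cm/s to 8.5 10^-6 cm/s.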

Compound 4, apparent permeability: 4.3 10^-6 cm/s
Compound 4: the middle estimate sits 1.1-fold (0.05 log units) below what was measured; measured number inside the range.
By their numbers in this assay, from the lowest: compounds 1 and 4 (each within the scatter of the next); then compound 3.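

In this assay, the exchange of methyl for oxolan-2-yl on the saturated chain carbon gives a 2.9-fold lower number from compound 3 to compound 4 (0.46 log units; beyond the scatter), so a lower number now also appears with this single, named change. Compound 1 also carries a five-membered non-aromatic ring with 1 hetero atom, and a 1.5-fold higher number from compound 1 to compound 4 (0.17 log units; within the scatter), so the two ring-bearing groups are not told apart in this assay. Nothing measured here gives a cause for either step.

The compounds shown leave open whether the lower number goes with the ring itself or with the larger group, a question that a propyl chain on the same saturated chain carbon would address. They also leave open where a pyrrolidine ring, with an amine nitrogen in place of the ring oxygen, would stand relative to compound 3 and compound 4.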